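A Cyano Swap in a Low-Toxicity Series

The source may report more compounds than this note shows. Statements on the series, on what has been measured and on what is new or still open speak of the compounds shown alone.

Three related compounds share one core and differ only in the ring group on the benzyl arm. Within the data shown here, in a toxicity assay on NIH3T3 cells (Mus musculus) for cytotoxicity, read by resazurin assay (a higher number here means that more compound is needed for the effect, a lower number that less compound is needed), compound 3 `COC(=O)c1ccc(NCc2cncn2Cc2ccccc2[N+](=O)[O-])cc1-c1ccccc1` gives 10000 nM, the only true number in the set. Compound 1 `COC(=O)c1ccc(NCc2cncn2Cc2ccc([N+](=O)[O-])cc2)cc1-c1ccccc1` gives > 10000 nM, which is a limit of the assay and not a number. Compound 2 `COC(=O)c1ccc(NCc2cncn2Cc2cccc(F)c2)cc1-c1ccccc1` gives > 1000 nM, which is also a limit.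

Compound 4 `COC(=O)c1ccc(NCc2cncn2Cc2ccc(C#N)cc2)cc1-c1ccccc1` carries 4-cyanophenyl in place of 2-nitrophenyl on a saturated chain carbon bound to an aromatic nitrogen.

The measured steps all change this same group, but none has a readable size. The nearest guide is a number no higher from compound 1 to compound 3 (the limit leaves the size open), since compound 1 carries 4-nitrophenyl and so shares the numbered position of the new group. The other two are a step that the two limits leave unreadable from compound 1 to compound 2 and a step that the limit leaves unreadable from compound 2 to compound 3, and they add little.

No measured change in this group has shown a clear rise in toxicity, so compound 3 at 10000 nM is the best anchor. The expected result is no change at the digits printed from compound 3 to compound 4 (within the scatter), with no change beyond the usual scatter. For compound 4 the estimated value is 10000 nM, with an expected range of 3000 nM to 30000 nM.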

Compound 4, half-maximal effective concentration: > 10000 nM
Compound 4 gave a limit, no number (the forecaster's own chance of this, stated with the estimate: 60%); the middle value lies on the limit itself.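

In this assay compound 4 gives > 10000 nM, which is a limit of the assay and not a number. The new information is that a group with no nitro on it, 4-cyanophenyl, gives a number no lower from compound 3 to compound 4 (the limit leaves the size open), so on this saturated chain carbon bound to an aromatic nitrogen a nitro group is not needed to keep the number this high. The steps from compound 1 and from compound 2 to compound 4 cannot be read in size, and compound 1 and compound 4 sit at one shared limit: the limit of > 10000 nM in this assay, at which 2 of the 4 values shown sit.

Going by these compounds, the true numbers of compound 1 and compound 4 stay open, and so does whether 4-cyanophenyl and 2-nitrophenyl differ at all in this assay. Also open, on these data alone, is whether 4-aminophenyl or 4-carboxyphenyl in the same place would bring the number down to a value that can be read.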